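The compounds below may be only part of what the source reports. "The series", "measured", "known", "first", "only" and "open" are said of these compounds alone.

Series notes. Compound 1 `O=c1c2cccnc2sn1-c1ccc([N+](=O)[O-])cc1` gives 4100 nM in an assay for inhibition of histone acetyltransferase KAT2B (Homo sapiens), read by fluorescence; on this read-out higher numbers stand for weaker inhibition and lower numbers for stronger inhibition. Among the measured compounds shown here, compound 2 `O=c1c2cccnc2sn1-c1ccccc1` gives 7850 nM in this assay and so stands highest of the two numbers, though the only step, a 1.9-fold higher number from compound 1 to compound 2 (0.28 log units; within the scatter), lies within the scatter. Compound 3 `COc1cccc(-n2sc3ncccc3c2=O)c1` differs from compound 2 by methoxy in place of hydrogen on an aromatic carbon. For the measured compounds named here, no measured step involves a methoxy; the one step seen, a 1.9-fold higher number from compound 1 to compound 2 (0.28 log units; within the scatter), shows that changing the group on this ring of compound 2 did not move the number beyond the scatter. Compound 3 is therefore expected to show a 1.1-fold lower number from compound 2 to compound 3 (0.05 log units; within the scatter) in this assay, with an estimated value of 7000 nM in the range 3000 nM to 18000 nM.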

Compound 3, half-maximal inhibitory concentration: 5030 nM
The estimate for compound 3 lay 1.4-fold (0.14 log units) above the measured number; low and high end bracket the measured number.
By their numbers in this assay, from the lowest: compounds 1, 3 and 2 (each within the scatter of the next).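

Methoxy on an aromatic carbon meta to a large group is the only change shown at this place on the ring, and it gives a 1.6-fold lower number from compound 2 to compound 3 (0.19 log units; within the scatter) in this assay. This place therefore accepts a methoxy without a move beyond the scatter. No evidence on the cause accompanies this result. Going by these compounds, whether an amine, a carboxylic acid or a longer chain at this place would move the number beyond the scatter remains open, as does whether any change on this ring can do so.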